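Acetyl for dimethylamino on the pendant phenyl ring

The compounds below may be only part of what the source reports. "The series", "measured", "known", "first", "only" and "open" are said of these compounds alone.

Compound 1 `COc1cc(C)cc(-c2c(-c3ccnc(-c4ccc(N(C)C)cc4)c3)cnn2CC#N)c1` is measured in a functional assay on OVCAR-4 cells (Homo sapiens) for cytotoxicity, read by sulforhodamine B assay, with a stated time of 48 h, tested at 100 nM; a higher number here means a weaker effect of the compound at the concentration tested, a lower number a stronger effect; compound 1 gives 33%. Compound 2 `COc1cc(C)cc(-c2nn(CC#N)cc2-c2ccnc(-c3ccc(N(C)C)cc3)c2)c1` sits level with it: in this assay compound 2 gives 33%, no change at the digits shown. Compound 3 `COc1cc(C)cc(-c2c(-c3ccnc(-c4ccc(C(C)=O)cc4)c3)cnn2CC#N)c1` is not yet measured. Relative to compound 1, compound 3 carries acetyl in place of dimethylamino on an aromatic carbon. Among the measured compounds shown here, no measured step of this kind is available. The step is expected to be modest, tending toward a higher number, though a result within the scatter is also possible. For compound 3 the estimate in this assay is 45% (range 20% to 75%), an expected step of a number 12 percentage points higher from compound 1 to compound 3 (beyond the scatter).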

Compound 3, a percentage reported as activity, at one concentration (the size of the read-out at that concentration, not a potency): 105%
The estimate for compound 3 lay 60 percentage points below the measured number; measured number above the stated range.
By their numbers in this assay, from the lowest: compounds 1 and 2 (each within the scatter of the next); then compound 3.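

In this assay, acetyl in place of dimethylamino on the pendant phenyl ring gives a number 72 percentage points higher from compound 1 to compound 3 (beyond the scatter), a much weaker effect at the concentration tested. Among the compounds shown here, this is the first sign that the position is not indifferent: the two groups are equal in heavy atom count, yet the read-out depends strongly on which one is present. Nothing measured on the compounds accounts for the step.

Going by these compounds, whether a smaller amine such as methylamino, or a methoxy group, keeps the effect of compound 1 remains open. Also open, on these data alone, is whether the same change behaves alike on the core of compound 2.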